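The source may hold more compounds than are shown below. What is called first, only, known or untested is meant among the compounds shown, and "the series" means these compounds.

Series notes. In a functional assay on SMMC-7721 cells (Homo sapiens) for inhibition, read by CCK-8 assay (a lower number here means a stronger inhibitor, a higher number a weaker inhibitor), compound 1 `Oc1ccccc1/C=N/c1nnc(SCc2nnc(-c3ccc(F)cc3)o2)s1` gives 13100 nM. Compound 2 `Oc1ccccc1/C=N/c1nnc(SCc2nnc(-c3ccc(Cl)cc3)o2)s1` gives 2840 nM. Compound 3 `Cc1ccccc1-c1nnc(CSc2nnc(/N=C/c3ccccc3O)s2)o1` gives 15500 nM, the highest of the three numbers; its gap to compound 1 lies within the scatter, while a 5.5-fold higher number from compound 2 to compound 3 (0.74 log units; beyond the scatter) lies beyond it. Compound 4 `O=[N+]([O-])c1ccc(-c2nnc(CSc3nnc(/N=C/c4ccccc4O)s3)o2)cc1` differs from compound 3 in one place: 4-nitrophenyl in place of 2-methylphenyl on an aromatic carbon. Going by the values given here, two measured steps bear on this position, a 1.2-fold higher number from compound 1 to compound 3 (0.07 log units; within the scatter) and a 5.5-fold higher number from compound 2 to compound 3 (0.74 log units; beyond the scatter), both changing the group on the same aromatic carbon. Among the compounds with values here, no measured compound carries a nitrophenyl group, so the direction rests only on compound 2 having the lowest number in this assay with a 4-substituted phenyl. For compound 4 a modest lower number is expected, a 1.9-fold lower number from compound 3 to compound 4 (0.29 log units; within the scatter), an estimate of 8000 nM within 2000 nM to 30000 nM.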

Compound 4, half-maximal inhibitory concentration: 16900 nM
For compound 4 the middle estimate is 2.1-fold (0.32 log units) below the measured one; measured number inside the range.
By their numbers in this assay, from the lowest: compound 2; then compounds 1, 3 and 4 (each within the scatter of the next).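

At this aromatic carbon, a 4-substituted phenyl alone does not bring the low number of compound 2 in this assay: nitro in place of chloro gives a 6.0-fold higher number from compound 2 to compound 4 (0.77 log units; beyond the scatter). Nitro and fluoro do not separate, with a 1.3-fold higher number from compound 1 to compound 4 (0.11 log units; within the scatter), and neither do 4-nitrophenyl and 2-methylphenyl, with a 1.1-fold higher number from compound 3 to compound 4 (0.04 log units; within the scatter). Among these four, only compound 2 stands apart, and no evidence at hand accounts for this. From the compounds shown here alone, whether 4-bromophenyl or 4-aminophenyl in this place would group with compound 2 or with compounds 1, 3 and 4 stays open.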